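A few compounds are considered here, and "the series" means these few. Any claim that something is new, unique, unknown or untested is made for them only; others in the source may bear on it.

Measured so far in a functional assay on CaEs17 cells (Homo sapiens) for cytotoxicity, read by MTT assay, with a stated time of 72 h; a higher number here means a weaker inhibitor, a lower number a stronger inhibitor:
- compound 1 `C=C1C(=O)[C@@]23C(=O)OC[C@]4([C@@H](OC(C)=O)CCC(C)(C)[C@H]4C=O)[C@@H]2CC[C@@H]1[C@H]3O` gives 72600 nM
- compound 2 `C=C1C(=O)[C@@]23C(=O)OC[C@]4(C(=O)CCC(C)(C)[C@H]4C=O)[C@@H]2CC[C@@H]1[C@H]3OC(=O)CC` gives 1400 nM

Of the two, compound 2 stands lower, with 1400 nM in this assay, and the gap to compound 1 lies well beyond the usual scatter of repeated measurements. Compound 1 and compound 2 differ in more than one place, so their gap cannot be tied to any single change.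

The next step leads to compound 3 `C=C1C(=O)[C@@]23C(=O)OC[C@]4(C(=O)CCC(C)(C)[C@H]4C=O)[C@@H]2CC[C@@H]1[C@H]3OC(=O)c1ccc(C(F)(F)F)cc1`, which keeps the rest of compound 2 and alters one group: 4-(trifluoromethyl)phenyl in place of ethyl on a carbonyl carbon. For the measured compounds named here, no measured pair differs in one place only, so the data give no direct size for such a change. The expectation therefore rests on compound 2 (1400 nM) as its anchor, and no step beyond the scatter is expected in this assay, with a slight lean toward the lower number. The expected step is a 1.3-fold lower number from compound 2 to compound 3 (0.10 log units; within the scatter) (an estimate only). For compound 3 the estimated value is 1100 nM (expected range 300 nM to 4000 nM).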

Compound 3, half-maximal inhibitory concentration: 8960 nM
Estimate against measurement, compound 3: 8.1-fold (0.91 log units) below, outside the stated range (above it).
By their numbers in this assay, from the lowest: compound 2; then compound 3; then compound 1.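

In this assay, putting 4-(trifluoromethyl)phenyl in place of ethyl on a carbonyl carbon gives a 6.4-fold higher number from compound 2 to compound 3 (0.81 log units; beyond the scatter), the first size available for a single change in this series, as compound 1 and compound 2 differ in more than one place. The result shows that this position is not indifferent to what the carbonyl carries: among these two groups, the propanoyl of compound 2 goes with the lower number, and the entering group, with its 10 heavy atoms in place of 2 and its aromatic ring, goes with the higher one. No measurement at hand accounts for the step.

The compounds shown leave open whether the step follows the aromatic ring itself or its trifluoromethyl group, a question that a plain phenyl on the same carbonyl carbon would address. Going by these compounds, it also remains open whether a longer chain such as butanoyl, or a chain ending in an amine, would stay near compound 2 or move towards compound 3 in this assay.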